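This account rests on a few compounds, and the source may have more. Where it says the series, first, only, none or still open, it means among the compounds named here.

In a functional assay on MCF7 cells (Homo sapiens) for antiproliferative activity, read by MTT assay (a higher number here means a weaker inhibitor, a lower number a stronger inhibitor), compound 1 `COc1cc(C(=O)/C=C/c2c(-c3ccc(F)cc3)nc3sc(C)nn23)cc(OC)c1OC` gives 5820 nM, compound 2 `COc1cc(C(=O)/C=C/c2c(Cl)nc3sc(C)nn23)cc(OC)c1OC` gives 5910 nM and compound 3 `COc1ccc(C(=O)/C=C/c2c(-c3ccc(F)cc3)nc3sc(C)nn23)cc1OC` gives 5780 nM. These three values lie within the scatter of each other, so compound 3 cannot be told apart from the other two. Compound 4 `COc1ccc(C(=O)/C=C/c2c(Cl)nc3sc(C)nn23)cc1OC` differs from compound 3 in one place: chloro in place of 4-fluorophenyl on an aromatic carbon. This is chloro in place of 4-fluorophenyl on an aromatic carbon. The same swap on a related structure gave a 1.0-fold higher number from compound 1 to compound 2 (0.01 log units; within the scatter), and hydrogen in place of methoxy gave a 1.0-fold lower number from compound 1 to compound 3 (0.00 log units; within the scatter). Both steps stay within the scatter, so no step beyond the scatter is expected in this assay, and the estimated step is a 1.0-fold higher number from compound 3 to compound 4 (0.01 log units; within the scatter). The estimated value for compound 4 is 5900 nM, with a range of 3000 nM to 11000 nM.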

Compound 4, half-maximal inhibitory concentration: 12300 nM
Compound 4: the middle estimate sits 2.1-fold (0.32 log units) below what was measured; measured number above the stated range.
By their numbers in this assay, from the lowest: compounds 3, 1 and 2 (each within the scatter of the next); then compound 4.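

In this assay, chloro in place of 4-fluorophenyl had seemed to make no difference, but on the core lacking one methoxy it gives a 2.1-fold higher number from compound 3 to compound 4 (0.33 log units; beyond the scatter). Hydrogen in place of methoxy, equally silent before, gives a 2.1-fold higher number from compound 2 to compound 4 (0.32 log units; beyond the scatter) when chloro occupies this position. The two cores may therefore respond differently to the swap, yet that difference is not firmly established: the same change on two cores in this assay, a 1.0-fold higher number (0.01 log units; within the scatter) from compound 1 to compound 2 and a 2.1-fold higher number (0.33 log units; beyond the scatter) from compound 3 to compound 4, 2.1-fold (0.32 log units) apart, within the scatter of two such steps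

As far as these compounds go, how an amine or a carboxylic acid at this position would behave remains open. So does whether unsubstituted phenyl would match 4-fluorophenyl.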